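Prolinamide Replacing an Alanine Amide on a Piperazine Core

The compounds below may be only part of what the source reports. "The series", "measured", "known", "first", "only" and "open" are said of these compounds alone.

Measured compounds:
- Compound 1 `CCCCCC(=O)c1ccc(OCCCN2CCN(C(=O)[C@@H](C)NC(=O)OC(C)(C)C)CC2)cc1`: 10700 nM
- Compound 2 `CC(C)N[C@H](C)C(=O)N1CCN(CCCOc2ccc(C(=O)C3CC3)cc2)CC1`: 50100 nM

Both compounds were tested in an assay for binding affinity to histamine H2 receptor (Homo sapiens); a higher number here means a weaker inhibitor, a lower number a stronger inhibitor. Among the measured compounds shown here, compound 2 gives the higher of the two numbers, so it is the weaker binder; compound 1, the only other compound, sits clearly lower, and that gap is beyond the usual scatter. The two compounds differ in more than one place, so nothing beyond these two values can be read from them.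

Compound 3 `O=C(c1ccc(OCCCN2CCN(C(=O)[C@H]3CCCN3)CC2)cc1)C1CC1` has not yet been measured. It differs from compound 2 in a single spot: pyrrolidin-2-yl in place of 1-(isopropylamino)ethyl on a carbonyl carbon. In words printed above, the open chain bearing a secondary amine is closed into a five-membered ring that keeps one hydrogen-bond donor and one acceptor, with the rest of the molecule unchanged.

For the measured compounds named here, no measured pair shows what this change does. Going by the values given here, with only two values to lean on, the step of a 1.7-fold lower number from compound 2 to compound 3 (0.22 log units; within the scatter) is expected to be small, most likely inside the scatter, perhaps a slight lowering of the number. Compound 3 is therefore estimated at 30000 nM, within a range from 8000 nM to 120000 nM.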

Compound 3, inhibition constant: 53700 nM
Estimate against measurement, compound 3: 1.8-fold (0.25 log units) below; the measured number falls inside the stated range.
By their numbers in this assay, from the lowest: compound 1; then compounds 2 and 3 (each within the scatter of the next).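

Among the compounds shown here, this is the first step in which only one part of the molecule differs. In this assay, putting pyrrolidin-2-yl in place of 1-(isopropylamino)ethyl on the carbonyl carbon gives a 1.1-fold higher number from compound 2 to compound 3 (0.03 log units; within the scatter), so the two compounds cannot be told apart in this measurement. For this one pair, then, tying the open chain into a five-membered ring, with one heavy atom fewer and the same count of hydrogen-bond donors and acceptors, leaves no visible mark on the number, although a single pair cannot show that this holds for other groups at the position. Nothing available here explains why the two groups read alike.

Still open, from the compounds shown here alone, is whether a different group on the same carbonyl carbon, such as a six-membered piperidin-2-yl ring or a 1-aminoethyl group carrying a primary amine, would separate from these two values beyond the scatter. Compound 1 differs from compound 2 in more than one place, so which of its parts sets its value also remains unanswered.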